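A few compounds are considered here, and "the series" means these few. Any claim that something is new, unique, unknown or untested is made for them only; others in the source may bear on it.

Measured so far:
compound 1 `CCCc1ccc(C(=O)Nc2cc3nc(C4CCCCC4)[nH]c3cc2N(C)C)cc1`: in an ADME assay on Vero cells (Chlorocebus sabaeus) for cytotoxicity, read by resazurin assay, with a stated time of 3 days (a lower number here means a stronger inhibitor, a higher number a weaker inhibitor), compound 1 reaches only the limit > 100 ug/mL.
compound 2 `CCCCCC(=O)Nc1cc2nc(C3CCCCC3)[nH]c2cc1N(C)C`: in this assay compound 2 likewise reaches only the limit > 100 ug/mL.

Compound 2 stands at the limit of this assay, as does compound 1; both values are limits rather than numbers, so the series gives no graded readout at all (the limit of > 100 ug/mL in this assay, at which 2 of the 2 values shown sit). Going by the values given here, the single measured step, a step that the two limits leave unreadable from compound 1 to compound 2, is unreadable in size, as both of its ends are limits.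

Compound 3 `CN(C)c1cc2[nH]c(C3CCCCC3)nc2cc1NC(=O)c1cccc(Br)c1` is not yet measured in this assay. It differs from compound 2 by 3-bromophenyl in place of pentyl on a carbonyl carbon. Among the compounds with values here, the one measured step changes the same carbonyl carbon, pentyl for 4-propylphenyl, and that step, a step that the two limits leave unreadable from compound 1 to compound 2, says nothing about direction or size. No measured evidence therefore points to a change; the aryl-bearing compound 1 and the alkyl-bearing compound 2 both sit at the limit, and the 3-bromophenyl of compound 3 is another aryl of comparable size.

Compound 3 is accordingly expected to sit at the same limit, the step of a number no higher from compound 2 to compound 3 (the limit leaves the size open) being none beyond the scatter. The estimate for compound 3 is 100 ug/mL, with a range from 50 ug/mL to 200 ug/mL.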

Compound 3, half-maximal inhibitory concentration: > 100 ug/mL
Compound 3 ended at the assay's limit; the forecaster's own chance of this, stated with the estimate: 80%; the middle value sits exactly at the limit.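

In this assay, going by these compounds alone, no step among compound 1, compound 2 and compound 3 can be read, each value being a limit and not a number. The compounds shown leave open how far any of the three lies from that limit, and whether changing the group on the carbonyl carbon alters the read-out at all.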